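A few compounds are considered here, and "the series" means these few. Any claim that something is new, unique, unknown or untested is made for them only; others in the source may bear on it.

Working notes on the solubility series.

In a physicochemical assay for solubility, read by chemiluminescence, in phosphate buffer, measured as kinetic solubility, at pH 7.4 (a lower number here means a less soluble compound, a higher number a more soluble compound), compound 2 `Cn1ccc(Nc2ccc(C(=O)NCC3(c4nc(-c5ccccc5)cs4)CCOCC3)cc2)n1` gives 48000 nM, the lowest of the two plain numbers recorded. Its nearest neighbour is compound 3 `COc1cccc(-c2csc(C3(CNC(=O)c4ccc(Cn5nc(C)cc5C)cc4)CCOCC3)n2)c1`, which in this assay gives 72000 nM; the gap between compound 2 and compound 3 is within the scatter, so no order is read into it. For compound 1 `O=C(NCC1(c2nc(-c3ccccc3)cs2)CCOCC1)c1ccc(CN2CCCCC2)cc1` this assay reports only a limit, >= 396000 nM, and not a number. Within the data shown here, the single measured step of one change is an at least 8.2-fold lower number from compound 1 to compound 2 (0.91 log units; beyond the scatter).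

Compound 4 `O=C(NCC1(c2nc(-c3ccccc3)cs2)CCOCC1)c1ccc(Nc2nncs2)cc1` is not yet measured. It differs from compound 2 by 1,3,4-thiadiazol-2-yl in place of 1-methyl-1H-pyrazol-3-yl on a nitrogen on an aromatic ring. Among the measured compounds shown here, no measured step exchanges one ring for another on that amino nitrogen; the step from compound 1 to compound 2 alters a different group at the same aromatic carbon, so it bears only loosely here. A step within the scatter is therefore expected for compound 4, as no change at the digits printed from compound 2 to compound 4 (within the scatter). The estimate for compound 4 in this assay is 48000 nM, in the range 20000 nM to 115000 nM.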

Compound 4, solubility: 29000 nM
For compound 4 the middle estimate is 1.7-fold (0.22 log units) above the measured one; the measured number falls inside the stated range.
By their numbers in this assay, from the lowest: compounds 4, 2 and 3 (each within the scatter of the next, the first and the last beyond it). At a limit, above all of these: compound 1.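

In this assay, exchanging one ring for another on the amino nitrogen gives a 1.7-fold lower number from compound 2 to compound 4 (0.22 log units; within the scatter), so the 1,3,4-thiadiazol-2-yl and 1-methyl-1H-pyrazol-3-yl groups cannot be told apart at this position. Against the (piperidin-1-yl)methyl group, the (1,3,4-thiadiazol-2-yl)amino group gives an at least 13-fold lower number from compound 1 to compound 4 (1.13 log units; beyond the scatter), the same direction as an at least 8.2-fold lower number from compound 1 to compound 2 (0.91 log units; beyond the scatter), so two different rings on the amino nitrogen now share that direction. Both of these longer steps start from a limit of the assay and not from a number: the limit of >= 396000 nM in this assay, at which 1 of the 4 values shown sits.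

Still open, on these data alone, is what a morpholine, a carboxylic acid or a plain amino group on that aromatic carbon would give. Also open, as far as these compounds go, is whether a saturated ring such as piperidine on the amino nitrogen would read with these two aromatic rings or with the (piperidin-1-yl)methyl group.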